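The source may hold more compounds than are shown below. What is called first, only, known or untested is meant among the compounds shown, and "the series" means these compounds.

Measured so far in an ADME assay on the whole organism (Rattus norvegicus, strain Sprague-Dawley) for pharmacokinetics, read by LC-MS; a lower number here means that more of the compound stays in the plasma, a higher number that more of the compound sits outside the plasma:
compound 1 `N#Cc1ccc(S(=O)(=O)N2C[C@H](S(=O)(=O)c3ccc(Cl)cc3)[C@](O)(CO)C2)c(Cl)c1` gives 4.5 L/kg
compound 2 `N#Cc1ccc(S(=O)(=O)N2C[C@H](S(=O)(=O)c3ccc(Cl)cc3)[C@](O)(CO)C2)cn1` gives 4.1 L/kg

Compound 2 stands level with compound 1 within the scatter. The step to compound 3 `N#Cc1ccc(S(=O)(=O)N2C[C@H](S(=O)(=O)c3ccc(Cl)cc3)[C@](O)(CO)C2)c(C(F)(F)F)n1` puts trifluoromethyl in place of hydrogen on an aromatic carbon. Within the data shown here, the only measured step is a 1.1-fold lower number from compound 1 to compound 2 (0.04 log units; within the scatter), at a group on a sulfonyl sulfur, and no measured step involves trifluoromethyl. No step beyond the scatter is therefore expected in this assay, and no direction can be called. The estimated change is a 1.1-fold higher number from compound 2 to compound 3 (0.03 log units; within the scatter) and fits that expectation. For compound 3 the estimate is 4.4 L/kg with an expected range from 2.4 L/kg to 8 L/kg once measured.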

Compound 3, volume of distribution at steady state: 3.6 L/kg
Compound 3: middle estimate off by 1.2-fold (0.09 log units), on the high side; the measured number falls inside the stated range.
By their numbers in this assay, from the lowest: compounds 3, 2 and 1 (each within the scatter of the next).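

In this assay, trifluoromethyl in place of hydrogen on an aromatic carbon next to the ring nitrogen gives a 1.1-fold lower number from compound 2 to compound 3 (0.06 log units; within the scatter), so this position accepts trifluoromethyl without a step beyond the scatter. The earlier compounds shown here showed a change only in the group on the sulfonyl sulfur, not a substitution at this ring carbon. No measurement of any property bears on this result. As far as these compounds go, whether an amine, a carboxylic acid or a longer chain at this position would move the number beyond the scatter remains open.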